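This account rests on a few compounds, and the source may have more. Where it says the series, first, only, none or still open, it means among the compounds named here.

In an ADME assay on microsomes from liver (Mus musculus) for metabolic stability, read by LC-MS, with NADPH named in the record, with a stated time of 60 min, tested at 1 uM, in the absence of a further agent (on this read-out lower numbers stand for a less stable compound and higher numbers for a more stable compound), compound 1 `COc1ccc(-c2c(C)nc3c(N4CC[C@@H](NC(=O)NC(C)C)C4)cc(C)nn23)cc1OC` gives > 95% and this is a limit, not a number. Compound 2 `COc1ccc(-c2c(C)nc3c(N4CC[C@@H](NS(=O)(=O)c5cccs5)C4)cc(C)nn23)cc1OC` gives > 95% and this too is a limit. Compound 2 therefore stands at the limit of > 95% in this assay, at which 2 of the 2 values shown sit, and has no exact reading. Within the data shown here, the one measured step is a step that the two limits leave unreadable from compound 1 to compound 2 and it offers no size to carry forward. Compound 3 `COc1ccc(-c2c(C)nc3c(N4CC[C@@H](NS(=O)(=O)c5ccc(C#N)cc5)C4)cc(C)nn23)cc1OC` keeps the core and the sulfonamide of compound 2 and changes one group: 4-cyanophenyl in place of thiophen-2-yl on a sulfonyl sulfur puts 4-cyanophenyl in place of thiophen-2-yl on a sulfonyl sulfur. With compound 2 at > 95% as a limit, no step beyond the scatter is expected in this assay although this rests on thin evidence. The expected size is a number at least 3 percentage points lower from compound 2 to compound 3 (that floor lies within the scatter) and any real shift could only be downward. Compound 3 is expected at 92% with an estimated range from 75% to 100%.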

Compound 3, percent of the compound remaining: > 95%
Compound 3: only a limit was reported; the forecaster's own chance of this, stated with the estimate: 50%; middle value at least 3 percentage points from the limit.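

Compound 1, compound 2 and compound 3 are each reported in this assay only as a limit, not as a number, so no step among them can be read: the limit of > 95% in this assay, at which 3 of the 3 values shown sit.

The compounds shown leave open whether thiophen-2-yl, 4-cyanophenyl and isopropylcarbamoyl differ at all in the percent of compound remaining.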